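Working notes: an oxolanyl swap in the series

This account rests on a few compounds, and the source may have more. Where it says the series, first, only, none or still open, it means among the compounds named here.

Going by the values given here, in a toxicity assay on L02 cells (Homo sapiens) for cytotoxicity, read by MTT assay, with a stated time of 72 h (on this read-out higher numbers stand for weaker inhibition and lower numbers for stronger inhibition), compound 1 (`O=C1c2c[n+]([O-])c3ccccc3c2C(=O)c2c1c1ccccc1n2Cc1cn([C@H]2O[C@H](CO)[C@@H](O)[C@H]2O)nn1`) gives 950 nM, the higher of the two numbers so far. Compound 2 (`CN1CCN(CCCCn2c3c(c4ccccc42)C(=O)c2c[n+]([O-])c4ccccc4c2C3=O)CC1`) gives 80 nM, lower by more than the scatter. Compound 3 (`O=C1c2c[n+]([O-])c3ccccc3c2C(=O)c2c1c1ccccc1n2Cc1cn([C@H]2C[C@H](O)[C@@H](CO)O2)nn1`) has 4-hydroxy-5-(hydroxymethyl)oxolan-2-yl in place of 3,4-dihydroxy-5-(hydroxymethyl)oxolan-2-yl on an aromatic nitrogen. Among the compounds with values here, no measured pair shows this change, so no step beyond the scatter is expected in this assay. The expected size is a 1.3-fold lower number from compound 1 to compound 3 (0.10 log units; within the scatter). The estimate for compound 3 is 750 nM, with an expected range of 280 nM to 2000 nM.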

Compound 3, half-maximal inhibitory concentration: 280 nM
Estimate against measurement, compound 3: 2.7-fold (0.43 log units) above; low and high end bracket the measured number.
By their numbers in this assay, from the lowest: compound 2; then compound 3; then compound 1.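

In this assay, the group on the aromatic nitrogen is shown to matter: 4-hydroxy-5-(hydroxymethyl)oxolan-2-yl in place of 3,4-dihydroxy-5-(hydroxymethyl)oxolan-2-yl gives a 3.4-fold lower number from compound 1 to compound 3 (0.53 log units; beyond the scatter). Going by these compounds alone, this modest step is the first read at this position, and the number falls with one hydroxyl fewer on the oxolane ring. Nothing measured on these compounds speaks to the reason for the step.

Still open, on these data alone, is whether fluorine in place of the remaining ring hydroxyl would move the number further. A carboxylic acid in place of the hydroxymethyl is equally untested by the compounds shown.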